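The source may hold more compounds than are shown below. What is called first, only, known or untested is meant among the compounds shown, and "the series" means these compounds.

Compound 1 `Nc1ccccc1NC(=O)/C=C/c1ccc(CSc2ccc(F)cc2)cc1`: 59.1%; compound 2 `Nc1ccccc1NC(=O)c1ccc(CSc2ccc(C(F)(F)F)cn2)cc1`: 38.9%; compound 3 `Cc1ccc(SCc2ccc(C(=O)Nc3ccccc3N)cc2)cc1`: 78.3%.

In a functional assay on A549 cells (Homo sapiens) for inhibition, read by CCK-8 assay, with a stated time of 72 h, tested at 8 uM (on this read-out lower numbers stand for less inhibition of growth and higher numbers for more inhibition of growth at the one concentration tested), compound 1 gives 59.1%, the second highest of the three numbers. Compound 3 gives 78.3%, higher than compound 1 by a margin beyond the scatter, and compound 2 gives 38.9%, lower than compound 1 by a margin beyond the scatter. Compound 4 `Nc1ccccc1NC(=O)/C=C/c1ccc(CSc2cccc(F)c2)cc1` differs from compound 1 in one place: 3-fluorophenyl in place of 4-fluorophenyl on a sulfur. Going by the values given here, no pair of measured compounds shows this change, so the expectation rests on compound 1 alone. The step is expected to be small, a number 2.1 percentage points lower from compound 1 to compound 4 (within the scatter), not beyond the scatter in either direction. Compound 4 is therefore estimated to give 57%, with a range from 42% to 72%.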

Compound 4, percent growth inhibition at one concentration: 56.6%
For compound 4 the middle estimate is 0.4 percentage points above the measured one, within the range that was stated.
By their numbers in this assay, from the lowest: compound 2; then compounds 4 and 1 (each within the scatter of the next); then compound 3.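

In this assay, going by these compounds alone, putting 3-fluorophenyl in place of 4-fluorophenyl on the sulfur gives a number 2.5 percentage points lower from compound 1 to compound 4 (within the scatter) and so offers the first direct reading at this position. On this core, at the one concentration tested, the two fluorophenyl groups cannot be told apart. Nothing measured here bears on why this is so. The compounds shown leave open whether an amine or a carboxylic acid in place of the fluorine would move the number beyond the scatter, and whether the same change would read alike on other cell lines.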